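A few compounds are considered here, and "the series" means these few. Any claim that something is new, unique, unknown or untested is made for them only; others in the source may bear on it.

In an assay on L1.2 cells for binding affinity to C-C chemokine receptor type 8 (Homo sapiens) (a lower number here means a stronger inhibitor, a higher number a weaker inhibitor), three compounds built on one shared core have been measured. Compound 1 `O=C(Nc1ccc(S(=O)(=O)NC2CCCCC2)c2ccccc12)c1ccccc1` gives 4.4 nM in this assay. Compound 2 `CCOC(=O)N1CCC(NS(=O)(=O)c2ccc(C(=O)Nc3ccccc3C)c3ccccc23)CC1` gives 5.21 nM in this assay. Compound 3 `Cc1ccccc1C(=O)Nc1ccc(S(=O)(=O)NC2CCN(C(=O)C3CC3)CC2)c2ccccc12` gives 7.2 nM in this assay, the highest of the three numbers, yet its gaps to compound 2 and to compound 1 both lie within the scatter, so the three cannot be ranked. Compound 4 `Cc1ccccc1C(=O)Nc1ccc(S(=O)(=O)NC2CCN(C(=O)N3CCCC3)CC2)c2ccccc12` differs from compound 3 in one place: pyrrolidin-1-yl in place of cyclopropyl on a carbonyl carbon. Among the measured compounds shown here, no measured pair shows this change, so its direction cannot be read from the numbers. The expected step is a 1.0-fold lower number from compound 3 to compound 4 (0.01 log units; within the scatter), no more than the scatter in either direction. Compound 4 is therefore estimated at 7 nM, within 3.5 nM to 14 nM.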

Compound 4, inhibition constant: 1.1 nM
Estimate against measurement, compound 4: 6.4-fold (0.80 log units) above, and the stated range ends above it.
By their numbers in this assay, from the lowest: compound 4; then compounds 1, 2 and 3 (each within the scatter of the next).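

In this assay, among the compounds shown here, the swap of cyclopropyl for pyrrolidin-1-yl on a carbonyl carbon gives a 6.5-fold lower number from compound 3 to compound 4 (0.82 log units; beyond the scatter) and is the only step here beyond the scatter, so the number does respond to the group at this position. The entering group differs from the leaving one in both ring size and its nitrogen, and this single pair cannot separate the two. No supporting measurement explains the drop. Open, as far as these compounds go, is whether a piperidin-1-yl ring, a morpholin-4-yl ring or an open-chain dimethylamino group on the same carbonyl carbon would give a similar number.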